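Swapping 5-methylthiophen-2-yl for pyridin-4-yl in compound 2

A few compounds are considered here, and "the series" means these few. Any claim that something is new, unique, unknown or untested is made for them only; others in the source may bear on it.

- Compound 1 `COc1ccc(-c2cnco2)cc1NCc1ccc(C)s1`: 42700 nM
- Compound 2 `COc1cc(NCc2ccc(C)s2)ccc1-c1cnco1`: 24700 nM
- Compound 3 `COc1ccc(-c2cnco2)cc1NCc1cccs1`: 53800 nM

In an ADME assay on Vero cells (Chlorocebus sabaeus) for cytotoxicity, read by MTT assay, with a stated time of 96 h (a lower number here means that less compound is tolerated, a higher number that more compound is tolerated), compound 2 gives 24700 nM, the low end of this small set: within the usual scatter of compound 1, but beyond it from compound 3. Compound 4 `COc1cc(NCc2ccncc2)ccc1-c1cnco1` carries pyridin-4-yl in place of 5-methylthiophen-2-yl on a saturated chain carbon bound to a nitrogen on an aromatic ring. Among the compounds with values here, only one measured step bears on this: a 1.3-fold higher number from compound 1 to compound 3 (0.10 log units; within the scatter). Within the data shown here, it touches just the methyl, and no measured compound carries pyridin-4-yl, so the guidance is weak. In this assay the expected result is a 1.4-fold higher number from compound 2 to compound 4 (0.15 log units; within the scatter), so no change beyond the scatter is expected. For compound 4 the estimate is 35000 nM, with an expected range of 14000 nM to 90000 nM.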

Compound 4, half-maximal cytotoxic concentration: 342000 nM
Beside the measured number, compound 4's estimate is 9.8-fold (0.99 log units) below it; measured number above the stated range.
By their numbers in this assay, from the lowest: compounds 2, 1 and 3 (each within the scatter of the next, the first and the last beyond it); then compound 4.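

At this place the group can matter a great deal in this assay: the ring swap gives a 14-fold higher number from compound 2 to compound 4 (1.14 log units; beyond the scatter), although the two groups match in heavy atoms and hydrogen-bond acceptors. So those counts do not account for the difference, and no measurement shown explains it.

Going by these compounds, whether the same rise would come with phenyl or pyridin-3-yl on this saturated chain carbon stays open. So does whether pyridin-4-yl would have a similar effect on the core of compound 1.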